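A few compounds are considered here, and "the series" means these few. Any claim that something is new, unique, unknown or untested is made for them only; others in the source may bear on it.

Compound 1, `CC(C)(C)c1csc(N)c1C(=O)c1ccc(Cl)cc1`, gives 1% in an assay on CHO cells for displacement of a labelled ligand from adenosine receptor A3 (Homo sapiens), read by scintillation counting, tested at 10 uM (a lower number here means less inhibition, a higher number more inhibition at the concentration tested (going by the name of the read-out)), a low read-out. Compound 2, `CC(C)(C)Cc1c(-c2ccncc2)sc(N)c1C(=O)c1ccc(Cl)cc1`, gives 6% in this assay; that is the higher of the two numbers recorded, but the gap to compound 1 lies within the scatter, so the two cannot be told apart. Compound 3, `CC(C)(C)Cc1c(/C=C/c2ccc(Cl)cc2)sc(N)c1C(=O)c1ccc(Cl)cc1`, has not been tested. It departs from compound 2 by a single change: 2-(4-chlorophenyl)ethenyl in place of pyridin-4-yl on an aromatic carbon. Among the compounds with values here, no step between measured compounds is available to guide an expectation, so the estimate rests on the two low numbers alone. A modest upward step is expected, a number 4 percentage points higher from compound 2 to compound 3 (within the scatter), and it may well stay within the scatter. For compound 3 the expected inhibition in this assay is therefore 10%, with a range from 0% to 35%.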

Compound 3, a percentage reported as inhibition, at one concentration (the size of the read-out at that concentration, not a potency): 11%
Beside the measured number, compound 3's estimate is 1 percentage points below it; measured number inside the range.
By their numbers in this assay, from the lowest: compounds 1, 2 and 3 (each within the scatter of the next).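

Within the data shown here, on the aromatic carbon next to the ring sulfur, 2-(4-chlorophenyl)ethenyl in place of pyridin-4-yl gives a number 5 percentage points higher from compound 2 to compound 3 (within the scatter) in this assay, the only step that can be read at this position. The entering group carries no hydrogen-bond acceptor where the leaving group carries one and adds a double bond outside aromatic rings and a chlorine, yet compound 3 at 11% stays low, so this exchange does not move the read-out beyond the scatter. No supporting measurement bears on this result.

The compounds shown leave open whether a carboxylic acid, a primary amine or a plain methyl group at this position would move the read-out beyond the scatter. They also leave open whether a saturated ethyl link in place of the ethenyl link would read the same.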